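The compounds below may be only part of what the source reports. "The series", "measured", "known", "first", "only" and "open" are said of these compounds alone.

Compound 2 `C/C=C/C1=CC2=CC(=O)[C@@](C)(OC(=O)c3c(C)cc(O)cc3O)C(=O)C2=CO1` and compound 1 `COC(=O)C1=CC2=CC(=O)[C@@](C)(O)[C@@H](OC(=O)c3c(C)cc(O)cc3O)[C@@H]2CO1` were both tested in an assay on isolated protein for inhibition of Alpha glucosidase (Homo sapiens), read by spectrophotometry, with stated times of 20 min and 1 min; on this read-out lower numbers stand for stronger inhibition and higher numbers for weaker inhibition. In this assay compound 2 gives only a limit of the assay, > 200000 nM. Compound 1 likewise gives only a limit, > 200000 nM. Both results sit at the limit of > 200000 nM in this assay, at which 2 of the 2 values shown sit, so compound 2 stands level with the one other compound shown. Compound 3 `Cc1cc(O)cc(O)c1C(=O)O[C@]1(C)C(=O)C=C2C=C(/C=C/CO)OC=C2C1=O` differs from compound 2 by hydroxy in place of hydrogen on a saturated chain carbon bound to a double-bonded chain carbon. Going by the values given here, with no measured step of this kind to draw on, the change is expected to bring no shift beyond the usual scatter, meaning a step of a number no higher from compound 2 to compound 3 (the limit leaves the size open). Compound 3 is therefore estimated at 200000 nM, within a range from 50000 nM to 1000000 nM, most likely reported again only as a limit.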

Compound 3, half-maximal inhibitory concentration: > 200000 nM
Compound 3 gave a limit, no number (the forecaster's own chance of this, stated with the estimate: 85%); the middle value lies on the limit itself.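

No step can be read between compound 2 and compound 3, since each result is only a limit of the assay, not a number. The compounds shown leave open whether hydroxy in place of hydrogen changes inhibition at all: the limit of > 200000 nM in this assay, at which 3 of the 3 values shown sit.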